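The compounds below may be only part of what the source reports. "The series", "measured", "known", "first", "only" and "open" are said of these compounds alone.

The compounds share a core on which an aryl group sits on a carbon with a double bond to nitrogen. Compound 1 `CC1=CC[C@H](C(C)(C)NC(=S)N/N=C/c2ccccc2O)CC1` carries a 2-hydroxyphenyl there, and in a functional assay on PC-3 cells (Homo sapiens) for inhibition, read by sulforhodamine B assay, with a stated time of 48 h (a lower number here means a stronger inhibitor of growth, a higher number a weaker inhibitor of growth), compound 1 gives 900 nM. Compound 2 `CC1=CC[C@H](C(C)(C)NC(=S)N/N=C/c2ccc(F)cc2)CC1` carries a 4-fluorophenyl instead; in this assay compound 2 gives < 900 nM, which is a limit of the assay and not a number (the limit of < 900 nM in this assay, at which 1 of the 3 values shown sits). Compound 3 `CC1=CC[C@H](C(C)(C)NC(=S)N/N=C/c2cccc(Cl)c2)CC1` carries a 3-chlorophenyl, and in this assay compound 3 gives 6600 nM, the highest of the two numbers shown. Its nearest neighbour is compound 1, reached by a 7.3-fold higher number from compound 1 to compound 3 (0.87 log units; beyond the scatter), while the step of an at least 7.3-fold higher number from compound 2 to compound 3 (0.86 log units; beyond the scatter) is read against a limit. Compound 4 `CC1=CC[C@H](C(C)(C)NC(=S)N/N=C/c2ccco2)CC1` differs from compound 3 in one place: furan-2-yl in place of 3-chlorophenyl on a carbon with a double bond to nitrogen. The measured steps that bear on this change are the two aryl swaps at the same carbon, a 7.3-fold higher number from compound 1 to compound 3 (0.87 log units; beyond the scatter) and an at least 7.3-fold higher number from compound 2 to compound 3 (0.86 log units; beyond the scatter), and in both the 3-chlorophenyl of compound 3 ends up with the higher number. Among the compounds with values here, the new aryl group of compound 4 has no measured counterpart, so the expectation rests on those two swaps alone. Compound 4 is expected to give an estimated 2500 nM in this assay, within a range from 700 nM to 9000 nM. The expected step is a 2.6-fold lower number from compound 3 to compound 4 (0.42 log units; beyond the scatter).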

Compound 4, concentration for total growth inhibition: 27200 nM
The estimate for compound 4 lay 11-fold (1.04 log units) below the measured number, outside the stated range (above it).
By their numbers in this assay, from the lowest: compound 1; then compound 3; then compound 4.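

In this assay, the aryl group on this carbon matters more than the two earlier swaps showed: the furan-2-yl of compound 4 gives a higher number than each of the three substituted phenyl groups, with a 4.1-fold higher number from compound 3 to compound 4 (0.62 log units; beyond the scatter), a 30-fold higher number from compound 1 to compound 4 (1.48 log units; beyond the scatter) and an at least 30-fold higher number from compound 2 to compound 4 (1.48 log units; beyond the scatter), which makes compound 4 the weakest inhibitor of growth of the four. The 3-chlorophenyl thus no longer marks the upper end at this position, and the step from a six-membered aromatic ring of carbon only to a five-membered aromatic ring with a hetero atom moves the number upward in every comparison shown, while the value of compound 2 is a limit of the assay and not a number: the limit of < 900 nM in this assay, at which 1 of the 4 values shown sits. Nothing measured here gives a reason for this rise.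

The compounds shown leave open whether the rise goes with the smaller ring or with its oxygen, which a thiophen-2-yl or an unsubstituted phenyl on this carbon could separate. They also leave open how a 4-chlorophenyl, or a phenyl carrying an amine or a carboxylic acid, would read in this assay.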